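Swapping the side chain on the shared core of compound 1

The compounds below may be only part of what the source reports. "The series", "measured", "known", "first", "only" and "open" are said of these compounds alone.

Three compounds carry measurements in an in vitro assay on 293-EBNA cells for binding affinity to corticotropin-releasing factor receptor 1 (Homo sapiens); a higher number here means a weaker inhibitor, a lower number a stronger inhibitor. Compound 1 `CCN(c1nc(C)nc2c1nnn2-c1ccc(C(C)C)cc1Br)C(COC)COC` gives 123 nM. Compound 2 `CCCCN(CC)c1nc(C)nc2c1nc(C(F)(F)F)n2-c1ccc(C(C)C)cc1Br` gives 1.4 nM. Compound 3 `CCCCN(CC)c1nc(C)nc2c1ncn2-c1c(Cl)cc(OC)cc1OC` gives 5.2 nM. Compound 1 therefore stands highest of the three, and its gaps to compound 3 and to compound 2 both lie beyond the usual scatter, so compound 1 is the weakest binder of the measured set. Within the data shown here, no two measured compounds differ in only one place, so no single step has a measured size.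

Compound 4 `COCC(COC)Oc1nc(C)nc2c1nnn2-c1ccc(C(C)C)cc1Br` is the one still to be measured. It differs from compound 1 as follows: a group of 8 heavy atoms (5 carbon, 3 oxygen; no ring) in place of a group of 10 heavy atoms (7 carbon, 1 nitrogen, 2 oxygen; no ring), on an aromatic carbon. The two chains are close in size and carry the same acceptor count; the leaving one is attached through nitrogen, the entering one through oxygen. In compounds 2 and 3 the corresponding position also carries a chain attached through nitrogen, so nothing measured shows what attachment through oxygen does here. A moderate weakening is expected, a 3.3-fold higher number from compound 1 to compound 4 (0.51 log units; beyond the scatter), with wide uncertainty. Compound 4 is expected to give 400 nM, within 120 nM to 1500 nM.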

Compound 4, inhibition constant: 7.1 nM
For compound 4 the middle estimate is 56-fold (1.75 log units) above the measured one; measured number outside the range, below it.
By their numbers in this assay, from the lowest: compound 2; then compounds 3 and 4 (each within the scatter of the next); then compound 1.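

In this assay, placing the chain attached through oxygen on this aromatic carbon, next to the ring nitrogen, in place of the chain attached through nitrogen gives a 17-fold lower number from compound 1 to compound 4 (1.24 log units; beyond the scatter). On the shared core of compound 1, attachment through nitrogen is therefore not required, and this position responds strongly to a swap between two chains close in size with the same acceptor count. The swap changes the attaching atom and the chain together, and nothing available explains the size of the step.

Among these compounds, the single step leaves the contributions of the attaching atom and the chain unseparated, and a chain attached through sulfur or a secondary amine would help to divide them. From the compounds shown here alone, whether the same swap carries over to the cores of compounds 2 and 3 also remains open.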